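The compounds below may be only part of what the source reports. "The series", "measured", "known", "first", "only" and "open" are said of these compounds alone.

Compound 1 `O=C(O)CCc1ccc(NCc2ccc(Cl)cc2)cc1` is the starting point for compound 4 `N#Cc1ccc(CNc2ccc(CCC(=O)O)cc2)cc1`. In a functional assay for agonist activity at Free fatty acid receptor 1 (Homo sapiens) (on this read-out lower numbers stand for an effect already at smaller amounts and higher numbers for an effect only at larger amounts of compound), compound 1 gives 1000 nM, the second highest of the three numbers recorded: compound 2 `O=C(O)CCc1ccc(NCc2ccc(Cl)c(Cl)c2)cc1` gives 251 nM, and compound 3 `O=C(O)CCc1ccc(NCc2cc(C(F)(F)F)cnc2Cl)cc1` gives 5010 nM. The change from compound 1 to compound 4 is cyano in place of chloro on an aromatic carbon. For the measured compounds named here, no measured step exchanges one substituent for another on this ring; the only step on it is a 4.0-fold lower number from compound 1 to compound 2 (0.60 log units; beyond the scatter), which adds a further chloro rather than replacing the first. It shows that the read-out responds to what sits on this ring, but gives no direction for a cyano. Compound 4 is therefore expected to land near compound 1, with a shift of a 2.0-fold higher number from compound 1 to compound 4 (0.30 log units; within the scatter) and wide uncertainty, the estimate being 2000 nM within 700 nM to 6000 nM.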

Compound 4, half-maximal effective concentration: < 31700 nM
Compound 4 gave a limit, no number; the forecaster's own chance of this, stated with the estimate: 5%; the middle value is on the limit's open side.
By their numbers in this assay, from the lowest: compound 2; then compound 1; then compound 3.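

For the compounds shown here, compound 4 gave only a limit, [ < 31700 nM ], not a number, so no step from compound 1 to compound 4 can be read. The compounds shown leave open how cyano in place of chloro shifts this read-out.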